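This account rests on a few compounds, and the source may have more. Where it says the series, first, only, none or still open, it means among the compounds named here.

Measured compounds in a functional assay on DU-145 cells (Homo sapiens) for inhibition, read by trypan blue exclusion, with a stated time of 96 h; on this read-out lower numbers stand for stronger inhibition of growth and higher numbers for weaker inhibition of growth:

- compound 1 `O=C(/C(=C\c1ccc(O)cc1O)SCc1cccc(Cl)c1)c1ccc(Br)cc1` gives 50000 nM
- compound 2 `CSc1ccc(/C=C(\C(=O)c2ccc(Cl)cc2)S(=O)(=O)Cc2ccc(Cl)cc2)cc1` gives 10000 nM
- compound 3 `Cc1ccc(/C=C(\C(=O)c2ccc(Cl)cc2)S(=O)(=O)Cc2ccc(Cl)cc2)s1` gives 1000 nM

Compound 2 stands second highest of the three numbers in this assay; its nearest neighbour is compound 1, which gives 50000 nM, and its furthest is compound 3, which gives 1000 nM.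

The unmeasured compound 4 `CSc1ccc(/C=C(\C(=O)c2ccc(Cl)cc2)S(=O)(=O)Cc2ccc(C)cc2)cc1` differs from compound 2 in one place: methyl in place of chloro on an aromatic carbon. The same difference, cut one bond further out, reads 4-chlorobenzyl to 4-methylbenzyl.

Within the data shown here, none of the measured steps bears directly on this change. Among the measured compounds shown here, the only step, a 10-fold lower number from compound 2 to compound 3 (1.00 log units; beyond the scatter), concerns a different place, the 5-methylthiophen-2-yl in place of 4-(methylsulfanyl)phenyl on a double-bonded chain carbon, and says nothing about the benzyl ring. Compound 1 differs from compound 2 in several places at once, so its value gives no single-point comparison either. For the measured compounds named here, with no step on this position in hand, the expectation is for no step in this assay beyond the scatter, in either direction.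

Compound 4 is therefore expected to give about 10000 nM in this assay, within 4000 nM to 25000 nM, which means an expected step of no change at the digits printed from compound 2 to compound 4 (within the scatter).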

Compound 4, concentration for 50% growth inhibition: 10000 nM
Beside the measured number, compound 4's estimate shows no gap at the digits printed, within the range that was stated.
By their numbers in this assay, from the lowest: compound 3; then compounds 2 and 4 (each within the scatter of the next); then compound 1.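

In this assay, among these compounds, the first reading on the benzyl ring is no change at the digits printed from compound 2 to compound 4 (within the scatter), so methyl in place of chloro on this aromatic carbon, para to a large group, leaves the number unmoved in this background. Of the two single-place changes now read in the series, only the 5-methylthiophen-2-yl in place of 4-(methylsulfanyl)phenyl change, a 10-fold lower number from compound 2 to compound 3 (1.00 log units; beyond the scatter), goes beyond the scatter, while 4-chlorobenzyl and 4-methylbenzyl cannot be told apart on this read-out. No evidence on why this exchange leaves the number flat is at hand.

Going by these compounds, whether the same flat reading holds when the benzyl change is carried by the 5-methylthiophen-2-yl compound remains open, as the change has been read only with the 4-(methylsulfanyl)phenyl group in place. A methoxy group, an amine, a carboxylic acid or a longer chain on the same aromatic carbon would show whether this position responds to anything beyond the exchange of chloro and methyl.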